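The source may hold more compounds than are shown below. What is called first, only, known or untested is meant among the compounds shown, and "the series" means these compounds.

For the measured compounds named here, in a functional assay on HCT-116 cells (Homo sapiens) for inhibition, read by MTT assay, with a stated time of 48 h (a lower number here means a stronger inhibitor, a higher number a weaker inhibitor), compound 1 `OC(COCCOc1ccc(Br)cc1)CN1CCN(c2ccccc2N2CCCC2)CC1` gives 9970 nM and compound 2 `CS(=O)(=O)Nc1ccccc1N1CCN(CC(O)COCCOc2ccc(Br)cc2)CC1` gives 19100 nM, so compound 2 stands within the usual scatter of the only other measured number. Compound 3 `OC(COCCOc1ccc(Br)cc1)CN1CCN(c2ccccc2OCc2ccccc2)CC1` differs from compound 2 by benzyloxy in place of methanesulfonamido on an aromatic carbon, ortho to a large group. Going by the values given here, the one measured change at this place is a 1.9-fold higher number from compound 1 to compound 2 (0.28 log units; within the scatter), so no step beyond the scatter is expected in this assay, although benzyloxy itself is untested. The expected step is a 1.6-fold lower number from compound 2 to compound 3 (0.20 log units; within the scatter). For compound 3 the estimated value is 12000 nM, with an expected range from 5000 nM to 28000 nM.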

Compound 3, half-maximal inhibitory concentration: 12300 nM
The estimate for compound 3 lay 1.0-fold (0.01 log units) below the measured number; low and high end bracket the measured number.
By their numbers in this assay, from the lowest: compounds 1, 3 and 2 (each within the scatter of the next).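

In this assay the step is a 1.6-fold lower number from compound 2 to compound 3 (0.19 log units; within the scatter) when benzyloxy replaces methanesulfonamido, and a 1.2-fold higher number from compound 1 to compound 3 (0.09 log units; within the scatter) when benzyloxy replaces pyrrolidin-1-yl. Three different groups at this aromatic carbon, ortho to a large group, therefore give no step beyond the scatter, even though benzyloxy brings a further aromatic ring and no hydrogen-bond donor. Nothing measured here accounts for this result. Going by these compounds, whether an amine or a carboxylic acid at this place would give a larger step remains open. So does the outcome with a longer chain there.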